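A few compounds are considered here, and "the series" means these few. Any claim that something is new, unique, unknown or untested is made for them only; others in the source may bear on it.

Compound 1 `O=C(Nc1cccc(-n2cc(-c3ccncc3)c(-c3ccc(Cl)c(O)c3)n2)c1)Nc1ccc(Cl)c(Cl)c1` gives 680 nM in a functional assay on HOP-92 cells (Homo sapiens) for inhibition, read by sulforhodamine B assay, with a stated time of 48 h; a higher number here means a weaker inhibitor, a lower number a stronger inhibitor.
Compound 2 `COc1cc(-c2nn(-c3cccc(NC(=O)c4ccccc4)c3)cc2-c2ccncc2)ccc1Cl` gives 320 nM in this assay.

Compound 1 stands highest of the two numbers; compound 2 gives the lower number, and that gap lies beyond the scatter. Compound 3 `O=C(Nc1cccc(-n2cc(-c3ccncc3)c(-c3ccc(Cl)c(O)c3)n2)c1)Nc1cccc(C(F)(F)F)c1` has not yet been measured. It differs from compound 1 in one place: 3-(trifluoromethyl)phenyl in place of 3,4-dichlorophenyl on an amide-type nitrogen. Going by the values given here, no step between measured compounds covers this change, so the expectation rests on compound 1 alone. The expected step, a 1.2-fold higher number from compound 1 to compound 3 (0.07 log units; within the scatter), is small: within the scatter, or a slight weakening at most. Compound 3 is estimated at 800 nM, range 350 nM to 1900 nM.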

Compound 3, half-maximal inhibitory concentration: 510 nM
Compound 3: middle estimate off by 1.6-fold (0.20 log units), on the high side; the measured number falls inside the stated range.
By their numbers in this assay, from the lowest: compounds 2, 3 and 1 (each within the scatter of the next, the first and the last beyond it).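

In this assay, 3-(trifluoromethyl)phenyl replaces 3,4-dichlorophenyl on the amide-type nitrogen with only a small step (a 1.3-fold lower number from compound 1 to compound 3 (0.12 log units; within the scatter)). At this position, then, these two substituted phenyl groups cannot be told apart, although the entering group has more heavy atoms. Nothing available explains why the two groups read alike.

Still open, from the compounds shown here alone, is whether this position accepts a group other than a substituted phenyl, such as a morpholine or a carboxylic acid on a longer chain. Going by these compounds, the effect of changing the 4-chloro-3-hydroxyphenyl part of the shared core with this urea kept in place also remains open.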